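The source may hold more compounds than are shown below. What is called first, only, known or untested is meant among the compounds shown, and "the series" means these compounds.

Measured in a functional assay on HepG2 cells (Homo sapiens) for inhibition, read by MTT assay, with a stated time of 48 h; a higher number here means a weaker inhibitor, a lower number a stronger inhibitor:
Compound 1 `COc1ccc(N(C)c2nc(C)nc3ccccc23)cc1OCCCCCC[Se]C#N`: 4890 nM
Compound 2 `COc1ccc(N(C)c2nc(C)nc3ccccc23)cc1C(=O)NCC[Se]C#N`: 179 nM
Compound 3 `COc1ccc(N(C)c2nc(C)nc3ccccc23)cc1OCCN`: 343 nM

Compound 3, at 343 nM, sits within the scatter of compound 2 (a 1.9-fold higher number from compound 2 to compound 3 (0.28 log units; within the scatter)) and far under compound 1 (a 14-fold lower number from compound 1 to compound 3 (1.15 log units; beyond the scatter)).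

The next molecule, compound 4 `COc1ccc(N(C)c2nc(C)nc3ccccc23)cc1OCCCCC[Se]C#N`, changes the end of the chain of compound 3: a group of 6 heavy atoms (4 carbon, 1 nitrogen, 1 selenium; no ring) in place of one nitrogen atom, on a saturated chain carbon, two bonds along the chain from an oxygen on an aromatic ring. This makes it resemble compound 1, which has a longer chain with the same selenium-bearing end. The best guide is therefore a 14-fold lower number from compound 1 to compound 3 (1.15 log units; beyond the scatter), read in reverse, which points to a large rise in the number. Compound 2 tempers this expectation. It also carries selenium, yet the data show a 27-fold lower number from compound 1 to compound 2 (1.44 log units; beyond the scatter), so selenium does not always accompany a high number. No measurement shows the effect of chain length alone. Taken together, the expected step is a 7.3-fold higher number from compound 3 to compound 4 (0.86 log units; beyond the scatter). For compound 4 the estimated value is 2500 nM, with an expected range from 700 nM to 8000 nM.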

Compound 4, half-maximal inhibitory concentration: 5210 nM
Estimate against measurement, compound 4: 2.1-fold (0.32 log units) below; low and high end bracket the measured number.
By their numbers in this assay, from the lowest: compounds 2 and 3 (each within the scatter of the next); then compounds 1 and 4 (each within the scatter of the next).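

In this assay, replacing the amino end of the chain with the selenium-bearing nitrile end is a large loss on its own (a 15-fold higher number from compound 3 to compound 4 (1.18 log units; beyond the scatter)). Chain length, which no earlier pair isolated, makes no difference beyond the scatter between the two ether-linked selenium chains (a 1.1-fold higher number from compound 1 to compound 4 (0.03 log units; within the scatter)). The way the selenium-bearing chain is attached to the shared core also matters, as the ether-linked chain of compound 4 and the amide-linked chain of compound 2 lie far apart (a 29-fold higher number from compound 2 to compound 4 (1.46 log units; beyond the scatter)).

No evidence on why these numbers differ is at hand. The compounds shown leave open how an amine on a longer chain, or a carboxylic acid at the chain end, would compare.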